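Lipophilicity of a polar amide replacement on the shared core

The source may report more compounds than this note shows. Statements on the series, on what has been measured and on what is new or still open speak of the compounds shown alone.

Compound 1 `COc1cccc(NC(=O)COc2cc(C)nc3ccc(OC)cc23)c1`: 4.49
Compound 2 `COc1ccc2nc(C)cc(OCC(=O)Nc3ccc(F)cc3)c2c1`: 4.49

Among the measured compounds shown here, in a physicochemical assay for lipophilicity, read by HPLC, in phosphate buffer, measured as chromatographic lipophilicity, at pH 7.4 (a lower number here means a more polar compound, a higher number a more lipophilic compound), compound 2 gives 4.49, level with compound 1 within the scatter; the only measured step, no change at the digits printed from compound 1 to compound 2 (within the scatter), swaps one aromatic ring for another and so says little about a change of kind. Compound 3 `COc1ccc2nc(C)cc(OCC(=O)NC3CONC3=O)c2c1` differs from compound 2 by a group of 6 heavy atoms (3 carbon, 1 nitrogen, 2 oxygen; one five-membered non-aromatic ring with 2 hetero atoms) in place of a group of 7 heavy atoms (6 carbon, 1 fluorine; one six-membered aromatic ring of carbon only), on an amide-type nitrogen. Nothing measured covers such a swap, but the entering group carries the counted donor and acceptors, so a marked fall in this assay is expected, a number 2.09 log units lower from compound 2 to compound 3 (beyond the scatter). Compound 3 is therefore estimated at 2.4, between 1.7 and 3.1.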

Compound 3, distribution coefficient: 0.79
Compound 3: middle estimate off by 1.61 log units, on the high side; the whole stated range lies above it.
By their numbers in this assay, from the lowest: compound 3; then compounds 1 and 2 (each within the scatter of the next).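

On the amide-type nitrogen, exchanging one aromatic ring for another had left the number unchanged, but in this assay the five-membered non-aromatic ring with 2 hetero atoms gives a number 3.70 log units lower from compound 2 to compound 3 (beyond the scatter) and likewise a number 3.70 log units lower from compound 1 to compound 3 (beyond the scatter) in the same place. This position therefore responds strongly to a change of ring kind, not just of ring substituent. Nothing shown here accounts for the size of these steps.

The ring, its donor and its acceptors enter together, and the compounds shown do not separate them. From the compounds shown here alone, whether a morpholine ring or a hydroxyethyl chain on that nitrogen would give a step of similar size stays open.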